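Tetrazolyl amide in place of a carboxyethyl amide

This account rests on a few compounds, and the source may have more. Where it says the series, first, only, none or still open, it means among the compounds named here.

Of the compounds shown here, two built on the same core have been measured in an assay on CHO cells for displacement of a labelled ligand from Glucagon receptor (Homo sapiens); on this read-out lower numbers stand for stronger inhibition and higher numbers for weaker inhibition. Compound 1 `O=C(O)CCNC(=O)c1ccc(Cc2cc(-c3ccc(OC(F)(F)F)cc3)n(C3CCCCC3)n2)cc1` gives 1700 nM in this assay. Compound 2 `O=C(O)CCNC(=O)c1ccc(Cc2cn(-c3ccc(OC(F)(F)F)cc3)nc2C2CCCCC2)cc1` gives 1200 nM in this assay; its number is the smaller of the two, but the difference from compound 1 lies within the scatter, so nothing sets the two apart. Compound 3 `O=C(Nc1nn[nH]n1)c1ccc(Cc2cn(-c3ccc(OC(F)(F)F)cc3)nc2C2CCCCC2)cc1` has not yet been measured. It differs from compound 2 in one place: 2H-tetrazol-5-yl in place of 2-carboxyethyl on an amide-type nitrogen. Within the data shown here, no pair of measured compounds shows what such a change does in this assay, so the expectation rests on compound 2 alone. The step of a 1.2-fold lower number from compound 2 to compound 3 (0.08 log units; within the scatter) that this estimate means is expected to be none beyond the scatter, in either direction. Compound 3 is therefore expected to give about 1000 nM in this assay, with a range from 300 nM to 4000 nM.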

Compound 3, half-maximal inhibitory concentration: 5300 nM
Compound 3: the middle estimate sits 5.3-fold (0.72 log units) below what was measured, outside the stated range (above it).
By their numbers in this assay, from the lowest: compounds 2 and 1 (each within the scatter of the next); then compound 3.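

In this assay the amide-type nitrogen turns out not to be indifferent to what it carries: 2H-tetrazol-5-yl in place of 2-carboxyethyl brings a 4.4-fold higher number from compound 2 to compound 3 (0.65 log units; beyond the scatter) on the shared core. The two groups are therefore not interchangeable at this place, although the step is modest and compound 3 still gives a measurable 5300 nM in this assay. No evidence is available on why the number rises with this change.

Left open is whether the step comes from the ring itself or from how it is attached, which a 2-(2H-tetrazol-5-yl)ethyl group or a shorter carboxymethyl group on the same nitrogen could separate. Also open is whether the same change would give a similar step on the core of compound 1, where the 2-carboxyethyl amide is the only form shown.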